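A few compounds are considered here, and "the series" means these few. Any claim that something is new, unique, unknown or untested is made for them only; others in the source may bear on it.

In an assay on isolated protein for inhibition of Tryptophan 2,3-dioxygenase (Homo sapiens), read by fluorescence and mass spectrometry, with stated times of 5 min and 15 min (a higher number here means a weaker inhibitor, a lower number a stronger inhibitor), compound 1 `CNc1oncc1-c1ccccc1` gives 190 nM. Compound 2 `CNC(=O)c1oncc1-c1ccccc1` gives only a limit of the assay, > 25000 nM; this is the limit of > 25000 nM in this assay, at which 1 of the 2 values shown sits. For the measured compounds named here, the one measured step is an at least 130-fold higher number from compound 1 to compound 2 (2.11 log units; beyond the scatter), so compound 2 stands at the weak end of what has been measured. Compound 3 `OCc1oncc1-c1ccccc1` differs from compound 2 by hydroxymethyl in place of methylcarbamoyl on an aromatic carbon. This undoes part of the change that separated compound 1 from compound 2, so a move back toward stronger inhibition is expected in this assay, though its size is uncertain. Compound 3 is expected to give 3000 nM, between 500 nM and 25000 nM, a shift of an at least 8.3-fold lower number from compound 2 to compound 3 (0.92 log units; beyond the scatter).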

Compound 3, half-maximal inhibitory concentration: 4400 nM
The estimate for compound 3 lay 1.5-fold (0.17 log units) below the measured number, within the range that was stated.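

Putting hydroxymethyl in place of methylcarbamoyl on the aromatic carbon next to the ring oxygen brings back measurable inhibition in this assay, with an at least 5.6-fold lower number from compound 2 to compound 3 (0.75 log units; beyond the scatter). Even so, hydroxymethyl does not recover all that methylamino gives at this position, with a 23-fold higher number from compound 1 to compound 3 (1.36 log units; beyond the scatter). The first of these steps gives only a minimum size, because compound 2 sits at a limit: the limit of > 25000 nM in this assay, at which 1 of the 3 values shown sits.

The compounds shown leave open how a plain amine, a dimethylamino group or a longer chain such as hydroxyethyl would compare with methylamino at this position.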